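Working notes: the step from compound 1 to compound 4

The compounds below may be only part of what the source reports. "The series", "measured", "known", "first", "only" and "open" are said of these compounds alone.

Measured in a functional assay on DU-145 cells (Homo sapiens) for inhibition, read by MTT assay, with a stated time of 48 h (a higher number here means a weaker inhibitor, a lower number a stronger inhibitor), so far
compound 1 `CS(=O)(=O)Nc1ccc(-n2cc(-c3ccccc3)nn2)cc1Oc1ccccc1` at 14200 nM
compound 2 `Cc1ccc(OCc2cn(-c3ccc(NS(C)(=O)=O)c(Oc4ccccc4)c3)nn2)cc1` at 8200 nM
compound 3 `CS(=O)(=O)Nc1ccc(-n2cc(COc3ccc4ccccc4c3)nn2)cc1Oc1ccccc1` at 9100 nM

Compound 1 lies within the scatter of both compound 2 and compound 3, so these numbers give no order among the three. Next is compound 4 `CS(=O)(=O)Nc1ccc(-n2cc(COc3ccc(Cl)cc3)nn2)cc1Oc1ccccc1`, which differs from compound 1 as follows: (4-chlorophenoxy)methyl in place of phenyl on an aromatic carbon with (4-chlorophenoxy)methyl in place of phenyl on an aromatic carbon.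

Going by the values given here, two measured steps bear on this change. The closest is a 1.7-fold lower number from compound 1 to compound 2 (0.24 log units; within the scatter) with (4-methylphenoxy)methyl in place of phenyl on an aromatic carbon. The other is a 1.1-fold higher number from compound 2 to compound 3 (0.05 log units; within the scatter) with naphthalen-2-yl in place of 4-methylphenyl on an oxygen on a saturated carbon. Both steps stay within the scatter, so no step beyond the scatter is expected in this assay here. The expected step is a 1.7-fold lower number from compound 1 to compound 4 (0.22 log units; within the scatter) and it remains an estimate. For compound 4 the estimated value is 8500 nM with an expected range of 4500 nM to 15000 nM pending measurement.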

Compound 4, half-maximal inhibitory concentration: 6400 nM
The estimate for compound 4 lay 1.3-fold (0.12 log units) above the measured number, and the stated range covers the measured number.
By their numbers in this assay, from the lowest: compounds 4, 2, 3 and 1 (each within the scatter of the next, the first and the last beyond it).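

In this assay, going by these compounds alone, placing (4-chlorophenoxy)methyl in place of phenyl on the aromatic carbon of the five-membered ring gives a 2.2-fold lower number from compound 1 to compound 4 (0.35 log units; beyond the scatter) and is the first step to clear the scatter, though only modestly. This does not establish a general gain for this kind of group, as compound 2 and compound 3 remain within the scatter of compound 1. Changes further out give no order, with chloro in place of methyl giving a 1.3-fold lower number from compound 2 to compound 4 (0.11 log units; within the scatter) and 4-chlorophenyl in place of naphthalen-2-yl giving a 1.4-fold lower number from compound 3 to compound 4 (0.15 log units; within the scatter) in the same assay. No measurement at hand offers a reason for these steps.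

Open, as far as these compounds go, is whether an amine or a carboxylic acid in place of chloro would shift the number beyond the scatter. Also open, from the compounds shown here alone, is how a longer chain in place of the methylene linking the oxygen to the five-membered ring would behave.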